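Moving the Carboxyl on the Benzyl Sulfide Arm

This account rests on a few compounds, and the source may have more. Where it says the series, first, only, none or still open, it means among the compounds named here.

Compound 2 `COc1ccc(CCCCCCCCOc2ccc(CSCc3ccc(C(=O)O)cc3)nc2/C=C/C(=O)O)cc1` gives 5.7 nM in an assay on isolated protein for displacement of a labelled ligand from leukotriene B4 receptor 1 (Homo sapiens) (a lower number here means a stronger inhibitor, a higher number a weaker inhibitor), the lower of the two numbers recorded, while compound 1 `COc1ccc(CCCCCCCCOc2ccc(C[S+]([O-])Cc3cccc(C(=O)O)c3)nc2/C=C/C(=O)O)cc1` gives 240 nM. Compound 3 `COc1ccc(CCCCCCCCOc2ccc(CSCc3ccccc3C(=O)O)nc2/C=C/C(=O)O)cc1` differs from compound 2 by 2-carboxyphenyl in place of 4-carboxyphenyl on a saturated chain carbon bound to a sulfur. Among the compounds with values here, the only measured step, a 42-fold lower number from compound 1 to compound 2 (1.62 log units; beyond the scatter), alters the carboxyl position together with the sulfur group, so it does not isolate a move of the carboxyl alone. A weakening beyond the scatter is therefore expected, a 5.3-fold higher number from compound 2 to compound 3 (0.72 log units; beyond the scatter), though with wide uncertainty. Compound 3 is estimated at 30 nM, with a range from 6 nM to 150 nM.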

Compound 3, inhibition constant: 112 nM
Compound 3: middle estimate off by 3.7-fold (0.57 log units), on the low side, within the range that was stated.
By their numbers in this assay, from the lowest: compound 2; then compound 3; then compound 1.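

With the sulfide arm otherwise unchanged, the step of a 20-fold higher number from compound 2 to compound 3 (1.29 log units; beyond the scatter) isolates the carboxyl move and shows that in this assay 2-carboxyphenyl is a much poorer replacement for 4-carboxyphenyl at this place. The modest step of a 2.1-fold lower number from compound 1 to compound 3 (0.33 log units; beyond the scatter) alters the carboxyl position together with the sulfur group, so it cannot separate the two changes. Nothing available explains the loss.

The compounds shown leave open how the carboxyl position and the sulfur group each contribute when changed alone. They also leave open whether a tetrazole could stand in for the carboxylic acid of 4-carboxyphenyl.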